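This account rests on a few compounds, and the source may have more. Where it says the series, first, only, none or still open, it means among the compounds named here.

Measured so far in a functional assay on HT-29 cells (Homo sapiens) for cytotoxicity, read by MTT assay, with a stated time of 72 h; a lower number here means a stronger inhibitor, a higher number a weaker inhibitor:
Compound 1 `COc1ccc(/C=C2\S/C(=N\c3csc(-c4ccc(Cl)cc4)c3)NC2=O)cc1` gives 3800 nM in this assay.
Compound 2 `CN(C)c1ccc(/C=C2\S/C(=N\c3csc(-c4ccc(Cl)cc4)c3)NC2=O)cc1` gives 1500 nM in this assay.
Compound 3 `O=C1N/C(=N/c2csc(-c3ccc(Cl)cc3)c2)S/C1=C\c1ccc(O)cc1` gives > 50000 nM in this assay, a limit of the assay and not a number.

Compound 3 thus stands at the limit (the limit of > 50000 nM in this assay, at which 1 of the 3 values shown sits), alone among the three measured compounds; the steps of an at least 13-fold higher number from compound 1 to compound 3 (1.11 log units; beyond the scatter) and an at least 33-fold higher number from compound 2 to compound 3 (1.52 log units; beyond the scatter) are both large. Compound 4 `CCCCCC/C=C1\S/C(=N\c2csc(-c3ccc(Cl)cc3)c2)NC1=O` differs from compound 3 by hexyl in place of 4-hydroxyphenyl on a double-bonded chain carbon bound to a double-bonded ring carbon. Going by the values given here, no measured step exchanges the aryl group for a chain; the steps known concern only the group on the phenyl ring, so they set no direction for this change. Compound 4 is therefore expected near 30000 nM in this assay, between 5000 nM and 200000 nM, an expected step of an at least 1.6-fold lower number from compound 3 to compound 4 (0.22 log units; that floor lies within the scatter) that is poorly anchored.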

Compound 4, half-maximal inhibitory concentration: 33500 nM
For compound 4 the middle estimate is 1.1-fold (0.05 log units) below the measured one; the measured number falls inside the stated range.
By their numbers in this assay, from the lowest: compound 2; then compound 1; then compound 4. At a limit, above all of these: compound 3.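

In this assay, hexyl on the double-bonded chain carbon gives a much higher number than either of the two ether- or amine-bearing aryl groups: a 22-fold higher number from compound 2 to compound 4 (1.35 log units; beyond the scatter), and an 8.8-fold higher number from compound 1 to compound 4 (0.95 log units; beyond the scatter). An aryl group at this place is therefore not sufficient on its own, as compound 3 also carries one, and a chain with no ring still gives a measurable number. The remaining step, an at least 1.4-fold lower number from compound 3 to compound 4 (0.17 log units; that floor lies within the scatter), gives only a floor and rests on a limit of the assay: the limit of > 50000 nM in this assay, at which 1 of the 4 values shown sits.

Open, on these data alone, is how a butyl chain, a longer chain or a chain ending in a carboxylic acid would read at this place. Also open, as far as these compounds go, is where an unsubstituted phenyl would fall.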